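The source may hold more compounds than are shown below. What is called first, only, known or untested is meant among the compounds shown, and "the series" means these compounds.

In a functional assay for inhibition, with Rattus norvegicus as the target (a higher number here means a weaker inhibitor, a lower number a stronger inhibitor), compound 3 (`C[C@@H](/N=c1\c(O)c(O)\c1=N/c1ccc(C#N)cc1)c1ccccc1`) gives 56 nM, the lowest number measured in this small set. Compound 1 (`CC(C)(C)/N=c1\c(O)c(O)\c1=N/c1ccc(C#N)cc1`) gives 560 nM. Compound 2 (`CCC(C)(C)/N=c1\c(O)c(O)\c1=N/c1ccc(C#N)cc1`) gives > 30000 nM, which is a limit of the assay and not a number. Compound 4 (`C[C@H](/N=c1\c(O)c(O)\c1=N/c1ccc(C#N)cc1)C1CCCCC1`) has not been measured. It carries 1-cyclohexylethyl in place of 1-phenylethyl on a double-bonded nitrogen. Among the measured compounds shown here, no measured step makes this exchange directly. The nearest are a 10-fold lower number from compound 1 to compound 3 (1.00 log units; beyond the scatter) and an at least 530-fold lower number from compound 2 to compound 3 (2.72 log units; beyond the scatter), which both change the group on that nitrogen. The step of an at least 53-fold higher number from compound 1 to compound 2 (1.72 log units; beyond the scatter) shows how far one added methyl can move the number, so the expectation stays wide. A modest step to a higher number is expected, a 2.7-fold higher number from compound 3 to compound 4 (0.43 log units; beyond the scatter). The estimated value for compound 4 is 150 nM, with an expected range from 20 nM to 1500 nM.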

Compound 4, half-maximal inhibitory concentration: > 30000 nM
Compound 4: only a limit was reported (the forecaster's own chance of this, stated with the estimate: 10%); at least 200-fold (2.30 log units) between middle value and limit.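

In this assay, the position on the double-bonded nitrogen proved to distinguish between two groups with the same count of heavy atoms: the non-aromatic ring of 1-cyclohexylethyl in place of the aromatic ring of 1-phenylethyl gives an at least 530-fold higher number from compound 3 to compound 4 (2.72 log units; beyond the scatter). The same group also compares poorly with tert-butyl, giving an at least 53-fold higher number from compound 1 to compound 4 (1.72 log units; beyond the scatter). The step between compound 2 and compound 4 cannot be read because both values are limits: the limit of > 30000 nM in this assay, at which 2 of the 4 values shown sit.

As far as these compounds go, what a pyridine ring or a methoxy-substituted phenyl ring would give here remains open. So does the effect of the opposite stereocentre on 1-phenylethyl.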